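The source may report more compounds than this note shows. Statements on the series, on what has been measured and on what is new or still open speak of the compounds shown alone.

Measured in a functional assay on HEp-2 cells (Homo sapiens) for inhibition; on this read-out higher numbers stand for an effect only at larger amounts of compound and lower numbers for an effect already at smaller amounts:
- compound 1 `CCOc1ncnc2c1nnn2[C@@H]1O[C@H](CO)[C@@H](O)[C@H]1O`: 0.1 uM
- compound 2 `CC(C)=CCNc1ncnc2c1nnn2[C@@H]1O[C@H](CO)[C@@H](O)[C@H]1O`: < 3 uM (a limit, not a number)

Compound 2 has no number in this assay; its < 3 uM is only a limit. the limit of < 3 uM in this assay, at which 1 of the 2 values shown sits, is all that can be said of its standing.

The change from there to compound 3 `OC[C@H]1O[C@@H](n2nnc3c(S)ncnc32)[C@H](O)[C@@H]1O` is sulfanyl in place of (3-methylbut-2-en-1-yl)amino on an aromatic carbon.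

For the measured compounds named here, one measured step bears on this: a step that the limit leaves unreadable from compound 1 to compound 2. It is also an exchange on an aromatic carbon, but it has no readable size to carry over. Neither measured compound carries sulfanyl, so the data give no direction for the new step and no firm size in this assay. Compound 1 at 0.1 uM sets the low end of what is expected, and the range is kept wide.

The expected change is a step that the limit leaves unreadable from compound 2 to compound 3, an estimate with little behind it. For compound 3 the estimated value is 1 uM, with an expected range from 0.1 uM to 10 uM.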

Compound 3, concentration for half-maximal effect: 1 uM
Beside the measured number, compound 3's estimate shows no gap at the digits printed; the measured number falls inside the stated range.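

In this assay, the position on the aromatic carbon of the six-membered ring now has its first readable step: sulfanyl in place of ethoxy gives a 10-fold higher number from compound 1 to compound 3 (1.00 log units; beyond the scatter). The number at this position therefore responds to the group placed there, and of the two exact values, the lower one belongs to the ethoxy compound, not the sulfanyl compound. Compound 2 is known only through a limit, < 3 uM, and the steps that involve it cannot be read, so (3-methylbut-2-en-1-yl)amino cannot yet be ranked against ethoxy or sulfanyl: the limit of < 3 uM in this assay, at which 1 of the 3 values shown sits.

Still open, on these data alone, is whether the step from ethoxy to sulfanyl follows the atom attached to the ring, the chain carried on that atom, or both, since the two groups differ in both respects. An ethylsulfanyl group or a plain amino group on the same carbon would help separate these two parts of the change, and a longer alkoxy chain such as propoxy would show whether the number moves with chain length on the same core.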